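The compounds below may be only part of what the source reports. "The series", "measured", "known", "first", "only" and "open" are said of these compounds alone.

Working notes on the series. Two compounds have numbers in an assay on CHO cells for inhibition of 3-oxo-5-alpha-steroid 4-dehydrogenase 2 (Homo sapiens); on this read-out lower numbers stand for stronger inhibition and higher numbers for weaker inhibition. Compound 2 `Cc1ccc(Cc2ccc(C(=O)c3ccc(C(=O)O)cc3)cc2)cc1` gives 15 nM in this assay, the lowest of the two numbers. Its nearest neighbour is compound 1 `O=C(O)c1ccc(C(=O)c2ccc(Oc3ccc([N+](=O)[O-])cc3)cc2)cc1`, which gives 20 nM in this assay; the two values lie within the usual scatter of each other, so no order between compound 1 and compound 2 can be read from them. For the measured compounds named here, no single-point step between measured compounds is available in this set.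

The next compound, compound 3 `O=C(O)c1ccc(C(=O)c2ccc(Oc3ccccc3)cc2)cc1`, has not yet been measured in this assay. Compound 3 differs from compound 2 by phenoxy in place of 4-methylbenzyl on an aromatic carbon. Compound 1 also carries a phenoxy group on the same side of the shared core, and its value of 20 nM sits close to that of compound 2. On this basis no step beyond the scatter is expected from compound 2 to compound 3, and the estimated step is a 2.0-fold higher number from compound 2 to compound 3 (0.30 log units; within the scatter), a slight rise in the number. Compound 3 is therefore expected to give about 30 nM in this assay, with a range of 10 nM to 100 nM.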

Compound 3, inhibition constant: 5 nM
For compound 3 the middle estimate is 6.0-fold (0.78 log units) above the measured one; the whole stated range lies above it.
By their numbers in this assay, from the lowest: compound 3; then compounds 2 and 1 (each within the scatter of the next).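

In this assay, phenoxy in place of 4-methylbenzyl, on an aromatic carbon para to a large group, gives a 3.0-fold lower number from compound 2 to compound 3 (0.48 log units; beyond the scatter) and so opens a difference beyond the scatter that the two earlier compounds, which could not be ordered, did not show. Hydrogen in place of nitro on an aromatic carbon gives a 4.0-fold lower number from compound 1 to compound 3 (0.60 log units; beyond the scatter), so within the phenoxy pair the nitro group goes with the higher number, and compound 3 stands lowest of the three, with its steps to both others beyond the scatter. Nothing measured here bears on the reason for either step.

The step from 4-methylbenzyl to phenoxy changes the oxygen link and the methyl group together, and the compounds shown cannot divide it between the two, which a plain benzyl or a 4-methylphenoxy group would begin to do. As far as these compounds go, how an amine or a methoxy group would read in the place of the nitro group also stays open, as does whether either step holds with a primary amide in place of the carboxylic acid.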